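The source may report more compounds than this note shows. Statements on the series, on what has been measured and on what is new or still open speak of the compounds shown alone.

In a functional assay on K562 cells (Homo sapiens) for antiproliferative activity, with a stated time of 72 h (a higher number here means a weaker inhibitor, a lower number a stronger inhibitor), compound 1 `OC[C@H]1O[C@@H](n2cnc3c(NCc4ccc(F)cc4)ncnc32)[C@H](O)[C@@H]1O` gives 2700 nM, and compound 2 `OC[C@H]1O[C@@H](n2cnc3c(NCc4ccc(Cl)c(Cl)c4)ncnc32)[C@H](O)[C@@H]1O` gives 10800 nM. Among the measured compounds shown here, compound 2 thus stands highest of the two numbers so far. Compound 3 `OC[C@H]1O[C@@H](n2cnc3c(NCc4ccc(F)c(Cl)c4)ncnc32)[C@H](O)[C@@H]1O` differs from compound 2 by fluoro in place of chloro on an aromatic carbon. For the measured compounds named here, the only measured step that bears on this is a 4.0-fold higher number from compound 1 to compound 2 (0.60 log units; beyond the scatter), in which 4-fluorophenyl became 3,4-dichlorophenyl. The 3-chloro-4-fluorophenyl of compound 3 lies between those two groups, so part of that step is expected to reverse, giving an expected 2.2-fold lower number from compound 2 to compound 3 (0.33 log units; beyond the scatter). Compound 3 is therefore estimated at 5000 nM, with a range of 2000 nM to 12000 nM.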

Compound 3, half-maximal inhibitory concentration: 5500 nM
Estimate against measurement, compound 3: 1.1-fold (0.04 log units) below, within the range that was stated.
By their numbers in this assay, from the lowest: compound 1; then compounds 3 and 2 (each within the scatter of the next).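

Fluoro and chloro on this aromatic carbon, para to a large group, are not separated by a 2.0-fold lower number from compound 2 to compound 3 (0.29 log units; within the scatter) in this series. The step that does clear the scatter is a 2.0-fold higher number from compound 1 to compound 3 (0.31 log units; beyond the scatter), so among these three compounds the added chloro, not the exchange of halogens, carries most of the rise seen in a 4.0-fold higher number from compound 1 to compound 2 (0.60 log units; beyond the scatter). Nothing at hand gives a reason for either step.
Still open, going by these compounds, is whether a methoxy group or an amine on that carbon would stay close to compound 3. Also open, on these data alone, is whether hydrogen there, with the chloro kept, would do the same.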